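Bromo for hydrogen on the core: cytotoxicity in breast cells

The compounds below may be only part of what the source reports. "The series", "measured", "known", "first", "only" and "open" are said of these compounds alone.

Compound 1, `CCN(CC)CN1C(=O)C(=O)c2c(Cl)cccc21`: 22500 nM
Compound 2, `O=C1C(=O)N(CN(c2ccccc2)c2ccccc2)c2cccc(Br)c21`: 98500 nM
Compound 3, `CCN(CC)CN1C(=O)/C(=N\c2nc3ccc(C)cc3s2)c2ccccc21`: 27500 nM

Three compounds have been run in an ADME assay on 184B5 cells (Homo sapiens) for cytotoxicity, read by sulforhodamine B assay, with a stated time of 48 h; a lower number here means a stronger inhibitor of growth, a higher number a weaker inhibitor of growth. Compound 3 holds the second highest of the three numbers. Its nearest neighbour is compound 1, whose value lies within the scatter of that of compound 3, so no order can be read between the two. Compound 2 stands furthest from compound 3, with a number beyond the scatter and higher than that of compound 3. Compound 2 differs from compound 3 in more than one place. Nothing can be said about what any single change did there.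

Compound 4, `CCN(CC)CN1C(=O)/C(=N\c2nc3ccc(C)cc3s2)c2c(Br)cccc21`, has not yet been measured in this assay. It differs from compound 3 by bromo in place of hydrogen on an aromatic carbon. Within the data shown here, no pair of measured compounds shows what this change alone does, and the three numbers available are all modest and close in kind. The step of a 1.1-fold higher number from compound 3 to compound 4 (0.04 log units; within the scatter) is therefore expected to be small, without a clear direction beyond the scatter. Compound 4 is estimated to give 30000 nM, with a range from 12000 nM to 75000 nM.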

Compound 4, concentration for 50% growth inhibition: 34300 nM
The estimate for compound 4 lay 1.1-fold (0.06 log units) below the measured number; the measured number falls inside the stated range.
By their numbers in this assay, from the lowest: compounds 1, 3 and 4 (each within the scatter of the next); then compound 2.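

In this assay, among these compounds, this pair gives the first reading of a single change, a 1.2-fold higher number from compound 3 to compound 4 (0.10 log units; within the scatter) for bromo in place of hydrogen on an aromatic carbon, ortho to a fused ring, and that step lies within the scatter. On the background of compound 3, then, adding one bromine atom at this position leaves no order that can be read between the two compounds. Nothing measured here speaks to why the number holds, and no cause can be given.

On these data alone, whether fluoro, methoxy or an amine on this same carbon would also leave the number unresolved remains open, as does bromo on another aromatic carbon of this ring. The other pairs differ in more than one place, so their steps cannot be read.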